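Cytotoxicity in the biaryl acid series: an ethylcarbamoyl variant

This account rests on a few compounds, and the source may have more. Where it says the series, first, only, none or still open, it means among the compounds named here.

Measured compounds:
- compound 1 `Cc1ccc(-c2c(C)c(-c3ccc(C)c(C)c3)c(C(OC(C)(C)C)C(=O)O)c(C)c2NS(C)(=O)=O)cc1C` — 15000 nM
- compound 2 `CCC(=O)Nc1c(C)c(C(OC(C)(C)C)C(=O)O)c(-c2ccc(C)c(C)c2)c(C)c1-c1ccc(C)c(C)c1` — 15000 nM
- compound 3 `Cc1ccc(-c2c(C)c(-c3ccc(Cl)cc3)c(C(OC(C)(C)C)C(=O)O)c(C)c2NS(C)(=O)=O)cc1C` — 26000 nM

Three members of the series have been tested in an ADME assay on MT4 cells (Homo sapiens) for cytotoxicity, read by MTT assay, with a stated time of 4 days; on this read-out lower numbers stand for higher toxicity in this test and higher numbers for lower toxicity in this test. Compound 1 gives 15000 nM, and compound 2 gives 15000 nM, so the two stand level at the digits shown and together form the lowest pair of the three numbers. Compound 3 gives 26000 nM, the highest of the three, though its distance from compound 1 remains within the scatter.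

Two single-point steps from compound 1 are known. The step of no change at the digits printed from compound 1 to compound 2 (within the scatter) swaps the methylsulfonyl on the ring nitrogen for propanoyl. The step of a 1.7-fold higher number from compound 1 to compound 3 (0.24 log units; within the scatter) changes one of the two aryl rings on the core.

Compound 4 `CCNC(=O)Nc1c(C)c(C(OC(C)(C)C)C(=O)O)c(-c2ccc(C)c(C)c2)c(C)c1-c1ccc(C)c(C)c1` is not yet measured. It differs from compound 1 by ethylcarbamoyl in place of methylsulfonyl on a nitrogen on an aromatic ring. The step that bears on it is the exchange at the same nitrogen, no change at the digits printed from compound 1 to compound 2 (within the scatter), which did not move the number beyond the scatter. On that basis no step beyond the scatter is expected in this assay, and the expected step of no change at the digits printed from compound 1 to compound 4 (within the scatter) is set close to zero.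

Compound 4 is therefore estimated at 15000 nM, with a range from 7000 nM to 32000 nM.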

Compound 4, half-maximal cytotoxic concentration: 15000 nM
Beside the measured number, compound 4's estimate shows no gap at the digits printed; the range from low to high includes it.
By their numbers in this assay, from the lowest: compounds 1, 2, 4 and 3 (each within the scatter of the next).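

In this assay the nitrogen on the aromatic ring now carries a third acyl-type group, and the step of no change at the digits printed from compound 1 to compound 4 (within the scatter) replaces methanesulfonamido with (ethylcarbamoyl)amino, so the entering group has a hydrogen-bond donor that methylsulfonyl lacks, yet the number holds. The step of no change at the digits printed from compound 2 to compound 4 (within the scatter) adds a second reading at the same place, with ethylamino in place of ethyl on a carbonyl carbon, so methylsulfonyl, propanoyl and ethylcarbamoyl all read alike here across these three compounds, with the other parts of the core kept the same. No supporting measurement is available to speak to this flat reading.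

The compounds shown leave open whether anything at this nitrogen can shift the number beyond the scatter, for instance a free amine, a chain ending in a carboxylic acid, or a longer chain in place of ethyl. They also leave open whether ethylcarbamoyl behaves the same way when 4-chlorophenyl stands in place of 3,4-dimethylphenyl on the shared core.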